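The source may hold more compounds than are shown below. What is called first, only, known or untested is meant among the compounds shown, and "the series" means these compounds.

In a functional assay (plasma) for inhibition, with Oryctolagus cuniculus as the target (a higher number here means that more compound is needed for the effect, a lower number that less compound is needed), compound 1 (`CCOC(=O)c1c(C)cc2cnn(-c3ccc(F)cc3)c(=O)c2c1C`) gives >= 50 uM, which is a limit of the assay. Compound 2 (`CCOC(=O)c1c(C)cc2cnn(-c3cccc(OC)c3)c(=O)c2c1C`) gives >= 50 uM, again a limit. Compound 3 (`CCOC(=O)c1ccc(-n2ncc3cc(C)c(C(=O)OCC)c(C)c3c2=O)cc1`) gives >= 50 uM, also only a limit. The series therefore stands at the limit of >= 50 uM in this assay, at which 3 of the 3 values shown sit, and compound 3 has no number of its own. Compound 4 (`CCOC(=O)c1c(C)cc2cnn(-c3ccc(S(C)(=O)=O)cc3)c(=O)c2c1C`) differs from compound 3 in one place: methylsulfonyl in place of ethoxycarbonyl on an aromatic carbon. For the measured compounds named here, the closest measured change is a step that the two limits leave unreadable from compound 1 to compound 3, and the only other is a step that the two limits leave unreadable from compound 1 to compound 2. Neither gives a size, so no step beyond the scatter is expected in this assay, in either direction. The expected step is a step that the limit leaves unreadable from compound 3 to compound 4. Compound 4 is estimated at 60 uM, with an expected range from 30 uM to 120 uM.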

Compound 4, concentration for half-maximal effect: >= 50 uM
Compound 4 gave a limit, no number; the forecaster's own chance of this, stated with the estimate: 85%; the middle value does not contradict the limit.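

Compound 4 gives only a limit, as do compound 1 and compound 3, so neither step to compound 4 can be read in this assay: the limit of >= 50 uM in this assay, at which 4 of the 4 values shown sit. The compounds shown leave open what actual concentration any of them needs for half-maximal effect.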